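The compounds below may be only part of what the source reports. "The series", "measured", "known", "first", "only" and "open" are said of these compounds alone.

Measured compounds:
compound 1, `Nc1scc(CN2CCN(c3cccnc3)CC2)c1C(=O)c1ccc(Cl)cc1`, in an assay on CHO cells for displacement of a labelled ligand from adenosine receptor A1 (Homo sapiens), read by scintillation counting, with a stated time of 120 min, tested at 10 uM (on this read-out higher numbers stand for more inhibition at the one concentration tested (going by the name of the read-out) and lower numbers for less inhibition), gives 0%
compound 2, `Nc1scc(CN2CCC(c3ccc(Cl)cc3)CC2)c1C(=O)c1ccc(Cl)cc1`, gives 0%
compound 3, `Nc1scc(CN2CCN(c3ccc(C(F)(F)F)cc3)CC2)c1C(=O)c1cccc(C(F)(F)F)c1`, gives 0%

All three share the same core, each carrying a six-membered ring with two nitrogens or one nitrogen and an aryl group attached through a methylene link. On the numbers shown, compound 1 stands level with compound 2 and with compound 3 at the digits recorded; the nearest is compound 2 and the furthest is compound 3, and in neither case does the gap reach beyond the usual scatter of this assay. Within the data shown here, no compound in this set shows any measurable displacement of the labelled ligand at the concentration tested.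

Compound 4, `Nc1scc(CN2CCN(c3cc(F)ccc3F)CC2)c1C(=O)c1ccc(Cl)cc1`, has not yet been measured. It differs from compound 1 in one place: 2,5-difluorophenyl in place of pyridin-3-yl on an amine nitrogen in a ring. The rest of the molecule, including the aminothiophene core and the chlorophenyl ketone, is unchanged.

Since compounds 1, 2 and 3 all sit at the same level in this assay, no step beyond the scatter is expected no change at the digits printed from compound 1 to compound 4 (within the scatter). Compound 4 is therefore expected to give 0% in this assay, within a range from -8% to 10%.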

Compound 4, a percentage reported as inhibition, at one concentration (the size of the read-out at that concentration, not a potency): 1%
Beside the measured number, compound 4's estimate is 1 percentage points below it; the range from low to high includes it.
By their numbers in this assay, from the lowest: compounds 1, 2, 3 and 4 (each within the scatter of the next).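

In this assay, among these compounds, 2,5-difluorophenyl in place of pyridin-3-yl on an amine nitrogen in a ring gives a number 1 percentage points higher from compound 1 to compound 4 (within the scatter), the first comparison here in which the molecule differs in only one place. Among the compounds shown here, at this position, then, a carbon-only aromatic ring carrying two fluorines cannot be told apart from an aromatic ring containing a nitrogen, even though the hydrogen-bond acceptor counted on pyridin-3-yl is absent from 2,5-difluorophenyl; with both readings so close to nothing, this shows only that neither group produces clear displacement of the labelled ligand at the one concentration tested, and the data offered here give no explanation for that.

What the compounds shown leave open is whether any group at this position can produce clear inhibition in this assay, since a step between two near-empty readings says little about how much this position can matter. Going by these compounds, a carboxylic acid, a primary amine or a longer alkyl chain such as hexyl on the same ring nitrogen would be a different kind of group from the aromatic rings seen so far, and how any of these would read remains unknown.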